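Swapping Fluoro for Cyano on the Sulfonyl Ring

The source may hold more compounds than are shown below. What is called first, only, known or untested is meant among the compounds shown, and "the series" means these compounds.

Of the compounds shown here, two sharing one core have been tested in a functional assay on NCI-H1975 cells (Homo sapiens) for inhibition, read by sulforhodamine B assay, tested at 10 uM; a lower number here means less inhibition, a higher number more inhibition at the concentration tested (going by the name of the read-out). Compound 1 `CN1CCN(c2ccc(C3=NNC(c4ccc(N(C)C)cc4)C3)cc2)CC1` carries a hydrogen on an amine nitrogen in a ring, and in this assay compound 1 gives 2.4%. Compound 2 `CN1CCN(c2ccc(C3=NN(S(=O)(=O)c4ccc(F)cc4)C(c4ccc(N(C)C)cc4)C3)cc2)CC1` carries a (4-fluorophenyl)sulfonyl on that nitrogen instead, and in this assay compound 2 gives 95.7%. Going by the values given here, that single change is the only measured step, a number 93.3 percentage points higher from compound 1 to compound 2 (beyond the scatter), and it places compound 2 highest of the two numbers, far beyond the scatter above compound 1.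

Compound 3 `CN1CCN(c2ccc(C3=NN(S(=O)(=O)c4ccc(C#N)cc4)C(c4ccc(N(C)C)cc4)C3)cc2)CC1` differs from compound 2 in one place: cyano in place of fluoro on an aromatic carbon. Among the compounds with values here, the one measured step concerns the sulfonyl group being present or absent, not the group on its aromatic ring, so no measured step bears directly on this change. The sulfonyl is kept, and compound 2 already gives a high number, 95.7%. Compound 3 is therefore expected to show a step of a number 5.7 percentage points lower from compound 2 to compound 3 (within the scatter) that stays within the scatter. Compound 3 is estimated at 90% in this assay, within a range from 70% to 99%.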

Compound 3, a percentage reported as inhibition, at one concentration (the size of the read-out at that concentration, not a potency): 100%
Beside the measured number, compound 3's estimate is 10 percentage points below it; measured number outside the range, above it.
By their numbers in this assay, from the lowest: compound 1; then compounds 2 and 3 (each within the scatter of the next).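

In this assay, the group on the aromatic ring of the sulfonyl can be cyano in place of fluoro with no readable change, as shown by a number 4.3 percentage points higher from compound 2 to compound 3 (within the scatter). The large gain from placing a sulfonyl on the ring nitrogen also holds with this second group, at a number 97.6 percentage points higher from compound 1 to compound 3 (beyond the scatter), so that gain is not tied to fluoro alone and appears with both the (4-fluorophenyl)sulfonyl and the (4-cyanophenyl)sulfonyl groups. No measurement at hand explains why either group is accepted or why the sulfonyl makes so large a difference.

From the compounds shown here alone, compound 3 gives 100% at a single tested concentration, and a read-out this close to the top of its scale leaves little room to tell compound 2 and compound 3 apart, so any difference in potency between them stays unknown. Going by these compounds, it also remains open whether an amine or a carboxylic acid on that same aromatic carbon would keep the number this high, and whether a simple methyl on the sulfonyl could stand in for the whole aromatic ring.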